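Bromo on the fused ring: notes on one small series

The compounds below may be only part of what the source reports. "The series", "measured", "known", "first", "only" and "open" are said of these compounds alone.

Measured compounds in a functional assay on cells (Cancer cell lines, Homo sapiens) for cytotoxicity, read by sulforhodamine B assay, with a stated time of 48 h; on this read-out lower numbers stand for stronger inhibition of growth and higher numbers for weaker inhibition of growth:
compound 1 `COc1ccc(C2=NN(C3=NC(=O)/C(=C4\C(=O)Nc5ccccc54)S3)C(c3ccc(Cl)cc3)C2)cc1`, 100000 nM
compound 2 `COc1ccc(C2=NN(C3=NC(=O)/C(=C4\C(=O)Nc5ccc(Br)cc54)S3)C(c3ccc(Cl)cc3)C2)cc1`, 140 nM
compound 3 `CN(C)c1ccc(C2CC(c3ccccc3)=NN2C2=NC(=O)/C(=C3\C(=O)Nc4ccccc43)S2)cc1`, 6370 nM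

Compound 2 differs from compound 1 by one change, (bromo in place of hydrogen on an aromatic carbon), and this gave a 710-fold lower number from compound 1 to compound 2 (2.85 log units; beyond the scatter) in this assay. The core of compound 3 differs from that of compound 1; the difference between the two cores is not broken down here. Compound 4 `CN(C)c1ccc(C2CC(c3ccccc3)=NN2C2=NC(=O)/C(=C3\C(=O)Nc4ccc(Br)cc43)S2)cc1` is not yet measured; it differs from compound 3 by bromo in place of hydrogen on an aromatic carbon, the same change as between compound 1 and compound 2, at the same place. Within the data shown here, the step from compound 3 to compound 4 is expected to be large, an 80-fold lower number from compound 3 to compound 4 (1.90 log units; beyond the scatter), resting on the size of a 710-fold lower number from compound 1 to compound 2 (2.85 log units; beyond the scatter), though only one such pair is known and the cores differ. Compound 4 is estimated at 80 nM in this assay, between 8 nM and 800 nM.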

Compound 4, concentration for 50% growth inhibition: 200 nM
Beside the measured number, compound 4's estimate is 2.5-fold (0.40 log units) below it; the measured number falls inside the stated range.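

In this assay, bromo in place of hydrogen on an aromatic carbon lowers the number on the second core as well, a 32-fold lower number from compound 3 to compound 4 (1.50 log units; beyond the scatter), so the direction of the change carries over between these two cores. Among these compounds, the size of the step does not carry over: the same change on two cores in this assay, a 710-fold lower number (2.85 log units; beyond the scatter) from compound 1 to compound 2 and a 32-fold lower number (1.50 log units; beyond the scatter) from compound 3 to compound 4, 22-fold (1.35 log units) apart, beyond the scatter of two such steps With only two pairs, this gives no general rule for other cores and does not show which of the differences between the cores goes with the gap.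

The compounds shown leave open whether another group at this place, such as fluoro, nitro or an amine, would give a step of similar direction and size. As far as these compounds go, it also remains open how bromo would behave elsewhere on the same ring.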